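A few compounds are considered here, and "the series" means these few. Any claim that something is new, unique, unknown or untested is made for them only; others in the source may bear on it.

Measured so far:
compound 1, `COc1ccc(NC(=O)c2cccc(Nc3ncc(F)c(Nc4ccc(F)cc4)n3)c2)cc1`: 11000 nM
compound 2, `CN(C)c1ccc(C(=O)Nc2cccc(Nc3ncc(F)c(Nc4ccc(F)cc4)n3)c2)cc1`: > 10000 nM

Going by the values given here, in a functional assay on A549 cells (Homo sapiens) for antiproliferative activity, read by sulforhodamine B assay, with a stated time of 3 days (on this read-out higher numbers stand for weaker inhibition of growth and lower numbers for stronger inhibition of growth), compound 1 gives 11000 nM, the only plain number among the two values shown. Compound 2 gives only a limit of the assay, > 10000 nM, and so sets no number. Compound 2 sits at the limit of > 10000 nM in this assay, at which 1 of the 2 values shown sits. Between these two compounds no step can be drawn, and where compound 1 stands is therefore fixed only against its own value: weak inhibition of growth.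

Compound 3, `CN(C)CC(=O)Nc1cccc(Nc2ncc(F)c(Nc3ccc(F)cc3)n2)c1`, is not yet measured. It differs from compound 1 as follows: (((dimethylamino)methyl)carbonyl)amino in place of (4-methoxyphenyl)carbamoyl on an aromatic carbon. Among the compounds with values here, no measured step of this kind is available, so the size of the change in this assay is open; with compound 1 already weak, the expectation is a step from compound 1 to compound 3 of no more than the scatter, in either direction. The estimate for compound 3 is then 10000 nM, with a range from 2500 nM to 40000 nM; the corresponding expected step is a 1.1-fold lower number from compound 1 to compound 3 (0.04 log units; within the scatter).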

Compound 3, concentration for 50% growth inhibition: 1180 nM
Estimate against measurement, compound 3: 8.5-fold (0.93 log units) above, and the stated range ends above it.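

In this assay, the position on the aromatic carbon proves sensitive to the group it carries: (((dimethylamino)methyl)carbonyl)amino in place of (4-methoxyphenyl)carbamoyl gives a 9.3-fold lower number from compound 1 to compound 3 (0.97 log units; beyond the scatter), which means stronger inhibition of growth. The dimethylamino group alone does not account for this, as it is present in both members of the second pair, where (dimethylamino)methyl in place of 4-(dimethylamino)phenyl on the carbonyl carbon gives an at least 8.4-fold lower number from compound 2 to compound 3 (0.92 log units; beyond the scatter). Compound 2 stands at a limit of the assay, so this second step is a bound only: the limit of > 10000 nM in this assay, at which 1 of the 3 values shown sits.

The two steps do not separate the loss of the six-membered aromatic ring from the other differences between the groups, and compound 3 is the only compound shown with a side group free of that ring. As far as these compounds go, it remains open whether the dimethylamino group matters within the ringless chain, which a comparison with a plain acetamide, a morpholine or a longer chain ending in the same amine could settle.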